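The source may hold more compounds than are shown below. What is called first, only, known or untested is meant among the compounds shown, and "the series" means these compounds.

Measured compounds:
compound 1 `Cc1ccc(-n2cc(NC(=O)c3cccc(NS(=O)(=O)c4ccccc4)c3)cn2)cc1` gives 1690 nM in a functional assay on MCF7 cells (Homo sapiens) for inhibition, read by MTT assay, with a stated time of 48 h; a higher number here means a weaker inhibitor, a lower number a stronger inhibitor
compound 2 `Cc1ccc(-n2cc(NC(=O)c3cccc(NS(=O)(=O)c4ccc(Cl)cc4)c3)cn2)cc1` gives 1080 nM
compound 3 `Cc1ccc(-n2cc(NC(=O)c3ccc(NS(=O)(=O)c4ccccc4)cc3)cn2)cc1` gives 10900 nM

Compounds 1 and 2 share one core and differ by chloro in place of hydrogen on an aromatic carbon. This change gives a 1.6-fold lower number from compound 1 to compound 2 (0.19 log units; within the scatter), so the two values do not separate within this series.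

Compound 3 carries the other core. Its value in this assay is the highest of the three, and its gap to compound 1 as well as its gap to compound 2 lies beyond the scatter. How the core of compound 3 differs from the core of compound 1 is not broken down here; the two have the same atoms joined differently.

Compound 4 `Cc1ccc(-n2cc(NC(=O)c3ccc(NS(=O)(=O)c4ccc(Cl)cc4)cc3)cn2)cc1` is the not yet measured partner of compound 3 and differs from it by chloro in place of hydrogen on an aromatic carbon. The place of the change reads word for word as for compound 1 to compound 2, so this is the same change set on the second core. Among the measured compounds shown here, only one measured instance of it exists, which is a thin basis. For the measured compounds named here, the single precedent is a 1.6-fold lower number from compound 1 to compound 2 (0.19 log units; within the scatter). Going by the values given here, because a 1.6-fold lower number from compound 1 to compound 2 (0.19 log units; within the scatter) is the only precedent, the step from compound 3 to compound 4 is expected to resemble it and is expected as a 1.6-fold lower number from compound 3 to compound 4 (0.19 log units; within the scatter). On this basis compound 4 is estimated at 7000 nM, with a likely range from 3500 nM to 14000 nM, the width reflecting that a step within the scatter could also go the other way.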

Compound 4, half-maximal inhibitory concentration: 3990 nM
For compound 4 the middle estimate is 1.8-fold (0.24 log units) above the measured one; the range from low to high includes it.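

In this assay, chloro in place of hydrogen on the phenylsulfonyl group gives a 2.7-fold lower number from compound 3 to compound 4 (0.44 log units; beyond the scatter), and set beside the same change on the core of compound 1, the two steps do not separate: the same change on two cores in this assay, a 1.6-fold lower number (0.19 log units; within the scatter) from compound 1 to compound 2 and a 2.7-fold lower number (0.44 log units; beyond the scatter) from compound 3 to compound 4, 1.7-fold (0.24 log units) apart, within the scatter of two such steps

So within these four compounds the change carries from one core to the other with no step size that can be told apart, although only the step on the core of compound 3 lies beyond the scatter on its own, and that step is a modest one. This rests on a single pair per core, one substituent, one ring position and one cell assay, so it does not show that other changes on this group would carry across in the same way, nor does it explain the effect of chloro or the gap between the two cores.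

Still open, going by these compounds, is whether a different group in the same place, such as methoxy, trifluoromethyl, an amine or a carboxylic acid, gives steps that also match on both cores. Also open, on these data alone, is whether replacing the methyl group on the other end of the molecule with a longer chain, or with chloro, would behave alike on the two cores.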